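This account rests on a few compounds, and the source may have more. Where it says the series, first, only, none or still open, it means among the compounds named here.

Compound 1 `Cc1ccc(S(=O)(=O)N2CCC(Br)CC2)cc1`: in a functional assay on SW1573 cells (Homo sapiens) for antiproliferative activity, read by sulforhodamine B assay, with a stated time of 48 h (on this read-out lower numbers stand for stronger inhibition of growth and higher numbers for weaker inhibition of growth), compound 1 gives > 100000 nM, a limit of the assay.
Compound 2 `Cc1ccc(S(=O)(=O)N2CC[C@@H](Br)C[C@@H]2CC(C)C)cc1`: compound 2 gives 22000 nM.
Compound 3 `CCCCCCC[C@H]1C[C@H](Br)CCN1S(=O)(=O)c1ccc(C)cc1`: compound 3 gives > 100000 nM, again a limit of the assay.

Compound 3 thus stands at the assay limit, as compound 1 does (the limit of > 100000 nM in this assay, at which 2 of the 3 values shown sit); only compound 2 has a measured number. Compound 4 `Cc1ccc(S(=O)(=O)N2CC[C@@H](Br)C[C@@H]2C2CCCCC2)cc1` is made from compound 3 by cyclohexyl in place of heptyl on a saturated ring carbon. Within the data shown here, two measured steps bear on this change: an at least 4.5-fold lower number from compound 1 to compound 2 (0.65 log units; beyond the scatter), and an at least 4.5-fold higher number from compound 2 to compound 3 (0.65 log units; beyond the scatter), while a step that the two limits leave unreadable from compound 1 to compound 3. A group other than heptyl on that carbon is therefore expected to give compound 4 a lower number, an at least 2.0-fold lower number from compound 3 to compound 4 (0.30 log units; that floor lies within the scatter), although its size cannot be read from a starting limit. Compound 4 is estimated at 50000 nM, within 15000 nM to 150000 nM.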

Compound 4, concentration for 50% growth inhibition: 82000 nM
For compound 4 the middle estimate is 1.6-fold (0.21 log units) below the measured one; the range from low to high includes it.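

With cyclohexyl on the saturated ring carbon next to the ring nitrogen, compound 4 gives a measured number in this assay, which heptyl in compound 3 did not, but isobutyl remains ahead of cyclohexyl: a 3.7-fold higher number from compound 2 to compound 4 (0.57 log units; beyond the scatter). The other two steps, an at least 1.2-fold lower number from compound 3 to compound 4 (0.08 log units; that floor lies within the scatter) and an at least 1.2-fold lower number from compound 1 to compound 4 (0.08 log units; that floor lies within the scatter), start from limits and have floors within the scatter, so neither establishes a real gain: the limit of > 100000 nM in this assay, at which 2 of the 4 values shown sit.

The compounds shown leave open how a shorter chain such as ethyl, a phenyl ring or an amine on that carbon would behave in this assay.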